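A few compounds are considered here, and "the series" means these few. Any claim that something is new, unique, unknown or untested is made for them only; others in the source may bear on it.

Measured in a functional assay on MCF7 cells (Homo sapiens) for inhibition, read by sulforhodamine B assay; a higher number here means a weaker inhibitor, a lower number a stronger inhibitor:
- compound 1 `O=C1C(NC2CCCC2)=CC(=O)c2c1nc1n2[C@H]2OC[C@@H](O)[C@H]2OC1`: > 16000 nM
- compound 2 `O=C1C(N2CCCCC2)=CC(=O)c2c1nc1n2[C@H]2OC[C@@H](O)[C@H]2OC1`: > 8000 nM

Neither entry is a number. Compound 2 is known only by a limit, > 8000 nM. Compound 1 is likewise known only by a limit, > 16000 nM. Going by the values given here, the two compounds differ in the group on a double-bonded ring carbon of the shared core, but a step that the two limits leave unreadable from compound 1 to compound 2 is the only measured step, and it offers no size to carry forward.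

Compound 3 `COc1ccc(NC2=CC(=O)c3c(nc4n3[C@H]3OC[C@@H](O)[C@H]3OC4)C2=O)cc1` places (4-methoxyphenyl)amino in place of piperidin-1-yl on that double-bonded ring carbon: (4-methoxyphenyl)amino in place of piperidin-1-yl on a double-bonded ring carbon. Among the compounds with values here, no measured step covers this exchange. Within the data shown here, with a step that the two limits leave unreadable from compound 1 to compound 2 as the sole guide, no firm direction can be expected in this assay, and weak inhibition similar to that of the two measured compounds is the cautious expectation. Another reading that is only a limit would be no surprise. For compound 3 the expected value is 10000 nM. The estimated range for compound 3 runs from 2500 nM to 32000 nM. The step expected is a step that the limit leaves unreadable from compound 2 to compound 3.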

Compound 3, half-maximal inhibitory concentration: 4470 nM
Compound 3: middle estimate off by 2.2-fold (0.35 log units), on the high side; the measured number falls inside the stated range.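

Among the compounds shown, compound 3 alone gives a number in this assay, so an amine substituent on this double-bonded ring carbon is no longer known only through limits. Exchanging cyclopentyl for 4-methoxyphenyl on the amine nitrogen gives an at least 3.5-fold lower number from compound 1 to compound 3 (0.55 log units; beyond the scatter), which shows that this change at this position can move the reading by more than the usual scatter. The comparison with the tertiary ring amine is less firm: exchanging piperidin-1-yl for (4-methoxyphenyl)amino gives an at least 1.7-fold lower number from compound 2 to compound 3 (0.25 log units; that floor lies within the scatter), and that floor alone does not separate the two groups.

The compounds shown leave open whether the aromatic ring or the methoxy group on it accounts for the difference, and a plain phenylamino group or a 4-chlorophenylamino group at the same carbon would bear directly on that question. Compound 1 is known only by a limit, so the full size of its step to the one measured number also remains open: the limit of > 16000 nM in this assay, at which 1 of the 3 values shown sits.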